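The source may hold more compounds than are shown below. What is called first, only, known or untested is meant among the compounds shown, and "the series" means these compounds.

Measured compounds:
compound 1, `O=C(Nn1c(-c2cccc([N+](=O)[O-])c2)nc2c(-c3ccc(F)cc3)n[nH]c2c1=O)c1cccnc1`: 24.7%
compound 2, `O=C(Nn1c(-c2cccc([N+](=O)[O-])c2)nc2c(-c3cccc(Cl)c3)n[nH]c2c1=O)c1ccccc1`: 89.8%
compound 3, `COc1cccc(-c2nc3c(-c4cccc(Cl)c4)n[nH]c3c(=O)n2NC(=O)c2ccccc2)c1`: 91%

In a functional assay on HT-29 cells (Homo sapiens) for cytotoxicity, read by sulforhodamine B assay, with a stated time of 2 days, tested at 100 uM (a lower number here means less inhibition, a higher number more inhibition at the concentration tested (going by the name of the read-out)), compound 2 gives 89.8%, the second highest of the three numbers. Among the compounds with values here, its nearest neighbour is compound 3, reached by the step of a number 1.2 percentage points higher from compound 2 to compound 3 (within the scatter), which is within the scatter; its furthest is compound 1, whose value of 24.7% lies far lower, though compound 1 differs from compound 2 in two places and no single step is drawn between them.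

Compound 4, `O=C(Nn1c(-c2cccc([N+](=O)[O-])c2)nc2c(-c3ccco3)n[nH]c2c1=O)c1ccccc1`, is the next compound, not yet measured. It differs from compound 2 in one place: furan-2-yl in place of 3-chlorophenyl on an aromatic carbon. Within the data shown here, the only measured step, from compound 2 to compound 3, concerns a methoxy in place of nitro on another aromatic carbon and so does not bear on this change; no measured pair alters the 3-chlorophenyl group. The expectation therefore rests on little. A moderate downward step a number 19.8 percentage points lower from compound 2 to compound 4 (beyond the scatter) is estimated, with wide uncertainty. Compound 4 is expected to give about 70%, within a range from 35% to 95%.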

Compound 4, a percentage reported as inhibition, at one concentration (the size of the read-out at that concentration, not a potency): 21.2%
Compound 4: middle estimate off by 48.8 percentage points, on the high side; the whole stated range lies above it.
By their numbers in this assay, from the lowest: compounds 4 and 1 (each within the scatter of the next); then compounds 2 and 3 (each within the scatter of the next).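

In this assay the group on this aromatic carbon, on the five-membered aromatic ring with 2 nitrogen, proves decisive: furan-2-yl in place of 3-chlorophenyl gives a number 68.6 percentage points lower from compound 2 to compound 4 (beyond the scatter), a large step. The earlier compounds kept 3-chlorophenyl unchanged across their one listed step, which is a number 1.2 percentage points higher from compound 2 to compound 3 (within the scatter) and concerns another aromatic carbon, so this is the first measured sign that the read-out depends on the group at this position. No measurement shown here accounts for the size of this step.

Within the data shown here, only two groups can be compared directly at this position, so it remains open whether the read-out follows the ring size, the chlorine or the ring oxygen. Going by these compounds, how an unsubstituted phenyl, a thiophene, an amine or a short alkyl chain would behave here also stays open, as does whether the same step would appear with methoxy in place of nitro.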